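Fluoro in place of hydrogen, repeated across two cores

A few compounds are considered here, and "the series" means these few. Any claim that something is new, unique, unknown or untested is made for them only; others in the source may bear on it.

Measured compounds:
compound 1 `Cc1cc(=O)n(-c2ccc(Br)cc2F)nc1C(=O)Nc1ccc(Oc2ncnc3ccsc23)cc1`: 9360 nM
compound 2 `Cc1cc(=O)n(-c2ccc(Br)cc2F)nc1C(=O)Nc1ccc(Oc2ncnc3ccsc23)c(F)c1`: 1550 nM
compound 3 `Cc1cc(=O)n(-c2ccccc2C(F)(F)F)nc1C(=O)Nc1ccc(Oc2ncnc3sccc23)cc1`: > 40000 nM, a limit of the assay, not a number

All values come from a functional assay on MCF7 cells (Homo sapiens) for cytotoxicity, read by MTT assay, with a stated time of 72 h; a lower number here means a stronger inhibitor, a higher number a weaker inhibitor. From compound 1 to compound 2 the change is fluoro in place of hydrogen on an aromatic carbon, and the step is a 6.0-fold lower number from compound 1 to compound 2 (0.78 log units; beyond the scatter). Compound 4 `Cc1cc(=O)n(-c2ccccc2C(F)(F)F)nc1C(=O)Nc1ccc(Oc2ncnc3sccc23)c(F)c1` stands to compound 3 as compound 2 stands to compound 1: the change is fluoro in place of hydrogen on an aromatic carbon, the same change at the same kind of place. The difference between the core of compound 1 and the core of compound 3 is not broken down here. For compound 3 this assay reports only (the limit of > 40000 nM in this assay, at which 1 of the 3 values shown sits). A step like the earlier one would be expected, but the start point for compound 3 is a limit, so the expected step of an at least 2.6-fold lower number from compound 3 to compound 4 (0.42 log units; beyond the scatter) is loosely anchored. Compound 4 is expected near 15000 nM, within 4000 nM to 40000 nM, and may itself return only a limit.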

Compound 4, half-maximal inhibitory concentration: 13800 nM
Estimate against measurement, compound 4: 1.1-fold (0.04 log units) above; measured number inside the range.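

In this assay, fluoro in place of hydrogen on an aromatic carbon again gives a lower number on the second core, with an at least 2.8-fold lower number from compound 3 to compound 4 (0.46 log units; beyond the scatter) as the step. The direction of the change therefore holds on both cores shown, but whether the size of the step carries over stays unresolved: the same change on two cores in this assay, a 6.0-fold lower number (0.78 log units; beyond the scatter) from compound 1 to compound 2 and an at least 2.8-fold lower number (0.46 log units; beyond the scatter) from compound 3 to compound 4; the limit leaves it open whether they differ. Compound 3 gives > 40000 nM, which is a limit and not a number, so its step has no upper end: the limit of > 40000 nM in this assay, at which 1 of the 4 values shown sits.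

As far as these compounds go, whether chloro or an amine at the same place would give a step of this kind stays open. So does whether the fluoro step holds on any third core.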